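A few compounds are considered here, and "the series" means these few. Any claim that something is new, unique, unknown or untested is made for them only; others in the source may bear on it.

Of the compounds shown here, two built on a shared core have been tested in an ADME assay on BJ cells (Homo sapiens) for cytotoxicity, read by CellTiter-Glo and resazurin assay, with a stated time of 72 h; on this read-out lower numbers stand for an effect already at smaller amounts and higher numbers for an effect only at larger amounts of compound. Compound 1 `CCOC(=O)CCCCCOc1cccc(CN(C(=O)c2ccc(-c3cnc(OC)nc3OC)cc2)C(C)C)c1` gives only the limit of > 26000 nM. Compound 2 `CCOC(=O)CCCCCOc1cccc(CN(C(=O)c2ccc(-c3cc(C(F)(F)F)cc(C(F)(F)F)c3)cc2)C(C)C)c1` likewise gives only the limit of > 26000 nM. Both values therefore sit at the same limit (the limit of > 26000 nM in this assay, at which 2 of the 2 values shown sit). Compound 3 `CCOC(=O)CCCCCOc1cccc(CN(C(=O)c2ccc(-c3cccc(C(F)(F)F)c3)cc2)C(C)C)c1` has not yet been measured and differs from compound 2 by hydrogen in place of trifluoromethyl on an aromatic carbon. Among the compounds with values here, no measured step between compounds shows the size of such a change, so no step beyond the usual scatter is expected in this assay, the estimated step being a step that the limit leaves unreadable from compound 2 to compound 3. Compound 3 is thus expected to give 30000 nM, within a range from 20000 nM to 60000 nM.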

Compound 3, half-maximal effective concentration: < 1.3 nM
Compound 3 gave a limit, no number; the forecaster's own chance of this, stated with the estimate: 85%; middle value at least 23000-fold (4.36 log units) away from the limit.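

In this assay, hydrogen in place of one trifluoromethyl on this aromatic carbon gives an at least 20000-fold lower number from compound 2 to compound 3 (4.30 log units; beyond the scatter), so a single group at this position can separate the two ends of the assay's range, which the two earlier compounds, both at the same limit, could not show. With 3-(trifluoromethyl)phenyl in place of 2,4-dimethoxypyrimidin-5-yl, the result is an at least 20000-fold lower number from compound 1 to compound 3 (4.30 log units; beyond the scatter). Both steps rest on limits, not on numbers: the limit of < 1.3 nM in this assay, at which 1 of the 3 values shown sits.

Going by these compounds, the true size of either step stays open. So does whether a single fluorine or an amine on this carbon, or a carboxylic acid in place of the ethyl ester, would keep the effect.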